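Cyclopentyl in place of hexyl on a thiadiazole carbamate

This account rests on a few compounds, and the source may have more. Where it says the series, first, only, none or still open, it means among the compounds named here.

Measured compounds:
compound 1 `O=C(NC1CCCC1)Oc1ccc(C2=NCCS2)cc1` 130 nM
compound 2 `O=C(NC1CCCC1)Oc1ccc(C2=NCCO2)cc1` 100 nM
compound 3 `CCCCCCNC(=O)Oc1ccc(-c2csnn2)cc1` 19 nM

Three carbamates have been measured in an assay on cell membranes (strain Wistar) for inhibition of Fatty-acid amide hydrolase 1 (Rattus norvegicus), read by scintillation counting; on this read-out higher numbers stand for weaker inhibition and lower numbers for stronger inhibition. Compound 1 and compound 2 share a cyclopentyl carbamate and differ only in the ring on the aromatic carbon; the step of a 1.3-fold lower number from compound 1 to compound 2 (0.11 log units; within the scatter) is within the scatter. Compound 3, with a hexyl carbamate and the thiadiazole ring, gives the lowest number of the three, and its distance from both compound 2 and compound 1 lies beyond the scatter.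

Compound 4 `O=C(NC1CCCC1)Oc1ccc(-c2csnn2)cc1` keeps the thiadiazole ring of compound 3 and differs from it in one place: cyclopentyl in place of hexyl on an amide-type nitrogen. Among the compounds with values here, no measured pair isolates this exchange. Within the data shown here, the only measured step, from compound 1 to compound 2, concerns the other end of the molecule and is within the scatter, so it offers no guide to the size or direction of the present change. Compound 1 and compound 2 show that the cyclopentyl carbamate is compatible with inhibition in this assay, but the hexyl-to-cyclopentyl exchange itself has not been followed.

Among the measured compounds shown here, with no direct precedent, compound 4 is expected to stay near compound 3, with a wide range allowed; the estimate is 30 nM (from 8 nM to 120 nM), which corresponds to an expected step of a 1.6-fold higher number from compound 3 to compound 4 (0.20 log units; within the scatter).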

Compound 4, half-maximal inhibitory concentration: 20 nM
Compound 4: middle estimate off by 1.5-fold (0.18 log units), on the high side; the measured number falls inside the stated range.
By their numbers in this assay, from the lowest: compounds 3 and 4 (each within the scatter of the next); then compounds 2 and 1 (each within the scatter of the next).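

In this assay, within the data shown here, the first direct reading of this exchange on the amide-type nitrogen gives a 1.1-fold higher number from compound 3 to compound 4 (0.02 log units; within the scatter) for cyclopentyl in place of hexyl, so on the thiadiazole carbamate the two groups cannot be told apart. Compound 4 also brings the thiadiazole ring onto the cyclopentyl carbamate, which allows the ring on the aromatic carbon to be compared with the cyclopentyl carbamate held constant: the measured steps are a 5.0-fold lower number from compound 2 to compound 4 (0.70 log units; beyond the scatter) against the oxygen-containing ring and a 6.5-fold lower number from compound 1 to compound 4 (0.81 log units; beyond the scatter) against the sulfur-containing non-aromatic ring. Both steps lie beyond the scatter, unlike the earlier exchange between the two non-aromatic rings, a 1.3-fold lower number from compound 1 to compound 2 (0.11 log units; within the scatter) and so, among these compounds, only the thiadiazole ring separates itself at this place.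

No supporting measurement accounts for any of these steps. On these data alone, whether hexyl and cyclopentyl also stay within the scatter of each other on the rings of compound 1 and compound 2, and how a cyclohexyl or benzyl group on the amide-type nitrogen would read, remains open.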